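Shortening an alkoxy chain on an aryl pyrazole amide

The compounds below may be only part of what the source reports. "The series", "measured", "known", "first", "only" and "open" are said of these compounds alone.

Measured compounds:
- compound 1, `O=C(Nc1cc(-c2ccccc2Cl)n[nH]1)C1Cc2ccccc2C1`: 450 nM
- compound 2, `COc1ccc(-c2cc(NC(=O)C3Cc4ccccc4C3)[nH]n2)cc1OC`: 33 nM
- compound 3, `CC(C)Oc1ccc(-c2cc(NC(=O)C3Cc4ccccc4C3)[nH]n2)cc1`: 92 nM

All three share a core, differing only in the substituents on the aryl ring. In an assay for binding affinity to Neuropeptide Y receptor type 5 (Homo sapiens) (on this read-out lower numbers stand for stronger inhibition and higher numbers for weaker inhibition), compound 3 sits second highest of the three numbers. Its nearest neighbour is compound 2, whose value is lower by a gap beyond the scatter, while compound 1 lies furthest away with a higher value, also beyond the scatter.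

Compound 4, `COc1ccc(-c2cc(NC(=O)C3Cc4ccccc4C3)[nH]n2)cc1`, is not yet measured. It differs from compound 3 in one place: methyl in place of isopropyl on an oxygen on an aromatic ring. Within the data shown here, no direct step between measured compounds covers this exact change, so the expectation rests on the values themselves. Compound 2, carrying two methoxy groups, gives 33 nM, the lowest number shown, which hints that a methoxy is tolerated well.

The step of a 1.5-fold lower number from compound 3 to compound 4 (0.19 log units; within the scatter) is expected to be small, pointing towards a lower number, but it may well fall within the scatter. Compound 4 is therefore estimated at 60 nM, within a range of 25 nM to 150 nM.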

Compound 4, inhibition constant: 62 nM
Estimate against measurement, compound 4: 1.0-fold (0.01 log units) below; the measured number falls inside the stated range.
By their numbers in this assay, from the lowest: compounds 2, 4 and 3 (each within the scatter of the next, the first and the last beyond it); then compound 1.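

In this assay, shortening isopropoxy to methoxy gives a 1.5-fold lower number from compound 3 to compound 4 (0.17 log units; within the scatter) and so shows that this oxygen substituent can be trimmed to methyl with no change that can be told from the scatter. Hydrogen in place of the second methoxy gives a 1.9-fold higher number from compound 2 to compound 4 (0.27 log units; within the scatter) and likewise leaves no readable change, so one methoxy on the aromatic ring is enough to stay in this range of numbers. Among these compounds, replacing the whole aryl group is different: 4-methoxyphenyl in place of 2-chlorophenyl gives a 7.3-fold lower number from compound 1 to compound 4 (0.86 log units; beyond the scatter) and is the only one of these steps that clears the scatter.

Still open, as far as these compounds go, is whether a longer chain such as butoxy, or an amine or a hydroxy group in place of the alkoxy, would keep the number in this range. Nothing available explains why the numbers fall as they do.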